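A Phenylpiperazine Amide in Place of the Arylhydrazide

This account rests on a few compounds, and the source may have more. Where it says the series, first, only, none or still open, it means among the compounds named here.

Compound 3 `O=C(Nc1sc2c(c1C(=O)NNc1ccc(Br)cc1)CCCCC2)NS(=O)(=O)c1ccccc1` gives 14800 nM in a functional assay on OVCAR-3 cells (Homo sapiens) for inhibition, with a stated time of 48 h (on this read-out higher numbers stand for weaker inhibition of growth and lower numbers for stronger inhibition of growth), the lowest of the two numbers shown, with compound 2 `O=C(Nc1sc2c(c1C(=O)NNc1ccccc1)CCCCC2)NS(=O)(=O)c1ccccc1` nearest at 15200 nM, a difference within the scatter. Compound 1 `NNC(=O)c1c(NC(=O)NS(=O)(=O)c2ccccc2)sc2c1CCCCC2` sits at the limit > 100000 nM in this assay. Compound 4 `O=C(Nc1sc2c(c1C(=O)N1CCN(c3ccccc3)CC1)CCCCC2)NS(=O)(=O)c1ccccc1` differs from compound 3 by 4-phenylpiperazin-1-yl in place of ((4-bromophenyl)amino)amino on a carbonyl carbon. For the measured compounds named here, no measured step makes this exchange; the nearest are an at least 6.5-fold lower number from compound 1 to compound 2 (0.81 log units; beyond the scatter) and an at least 6.7-fold lower number from compound 1 to compound 3 (0.82 log units; beyond the scatter), where phenyl replaced hydrogen on an amine nitrogen, and a 1.0-fold lower number from compound 2 to compound 3 (0.01 log units; within the scatter). Compound 4 keeps a phenyl ring at the end of the side group, so a step of a 1.2-fold lower number from compound 3 to compound 4 (0.09 log units; within the scatter) is expected, within the scatter. Compound 4 is therefore estimated at 12000 nM, between 4000 nM and 40000 nM.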

Compound 4, concentration for 50% growth inhibition: 11900 nM
Compound 4: the middle estimate sits 1.0-fold (0.00 log units) above what was measured; low and high end bracket the measured number.
By their numbers in this assay, from the lowest: compounds 4, 3 and 2 (each within the scatter of the next). At a limit, above all of these: compound 1.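

On this carbonyl carbon, 4-phenylpiperazin-1-yl, with 0 hydrogen-bond donors, takes the place of the arylhydrazide side groups in this assay without a change beyond the scatter: a 1.2-fold lower number from compound 3 to compound 4 (0.09 log units; within the scatter), and a 1.3-fold lower number from compound 2 to compound 4 (0.11 log units; within the scatter). The hydrogen-bond donors of the leaving groups are therefore not required for this level of growth inhibition. Compound 1 stands at a limit, so an at least 8.4-fold lower number from compound 1 to compound 4 (0.92 log units; beyond the scatter) gives only a bound: the limit of > 100000 nM in this assay, at which 1 of the 4 values shown sits.

Still open, going by these compounds, is what a morpholine or a simple dimethylamine on this carbonyl carbon, with no phenyl ring, would give. Also open, on these data alone, is whether a substituent such as methoxy on the phenyl ring of the piperazine would move the number beyond the scatter.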